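The compounds below may be only part of what the source reports. "The series", "measured", "known", "first", "only" and "open" are said of these compounds alone.

Series notes. Compound 1 `CCc1cccc2c(OC)c(-c3occ(C)c3C(=O)OC)ccc12` is the reference point. In a functional assay on SK-BR-3 cells (Homo sapiens) for cytotoxicity, read by MTT assay, with a stated time of 72 h (a higher number here means that more compound is needed for the effect, a lower number that less compound is needed), compound 1 gives 1.2 ug/mL. Compound 2 `CCOc1c(-c2occ(C)c2C(=O)OC)ccc2c(CC)cccc12` carries methyl in place of hydrogen on a saturated chain carbon bound to an oxygen on an aromatic ring; in this assay compound 2 gives 1.9 ug/mL. The step of a 1.6-fold higher number from compound 1 to compound 2 (0.20 log units; within the scatter) is small. Compound 3 `CCc1cccc2c(OC)c(-c3occ(C)c3COC)ccc12` differs from compound 1 in the core, namely (methoxymethyl in place of methoxycarbonyl on an aromatic carbon). For compound 3 this assay reports only a limit, > 10 ug/mL. The step of an at least 8.3-fold higher number from compound 1 to compound 3 (0.92 log units; beyond the scatter) is the one clear movement so far, and it involves (the limit of > 10 ug/mL in this assay, at which 1 of the 3 values shown sits).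

Compound 4 `CCOCc1c(C)coc1-c1ccc2c(CC)cccc2c1OC` is not yet measured. Relative to compound 3 it carries methyl in place of hydrogen on a saturated chain carbon bound to an oxygen on a saturated carbon. Among the compounds with values here, this is the same kind of change as the one from compound 1 to compound 2, but not the same change: there the methyl entered on a saturated chain carbon bound to an oxygen on an aromatic ring, here on a saturated chain carbon bound to an oxygen on a saturated carbon. Within the data shown here, the one measured instance of this kind, a 1.6-fold higher number from compound 1 to compound 2 (0.20 log units; within the scatter), stayed within the scatter. In this assay the step that the limit leaves unreadable from compound 3 to compound 4 is expected to be similarly small, resting on the step of a 1.6-fold higher number from compound 1 to compound 2 (0.20 log units; within the scatter). Compound 4 is therefore expected near 15 ug/mL, with a likely range from 6 ug/mL to 40 ug/mL, and a fair chance that only a limit is reported again.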

Compound 4, concentration for half-maximal effect: > 10 ug/mL
Compound 4: no number, only a limit; the forecaster's own chance of this, stated with the estimate: 65%; the middle value is on the limit's open side.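

In this assay compound 4 gives > 10 ug/mL, which is a limit and not a number. The step from methoxymethyl to ethoxymethyl therefore cannot be read, so the transfer of the methyl change to this second setting is neither confirmed nor contradicted, and a 1.6-fold higher number from compound 1 to compound 2 (0.20 log units; within the scatter) remains the only sized instance of this kind of change: the limit of > 10 ug/mL in this assay, at which 2 of the 4 values shown sit.

From the compounds shown here alone, the readable result concerns the replacement of methoxycarbonyl rather than the transfer itself: ethoxymethyl gives an at least 8.3-fold higher number from compound 1 to compound 4 (0.92 log units; beyond the scatter), and methoxymethyl gives an at least 8.3-fold higher number from compound 1 to compound 3 (0.92 log units; beyond the scatter), so both replacements in the shared core read the same way against compound 1, while their order relative to each other stays unknown.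

Open, going by these compounds, is whether any other group in place of methoxycarbonyl, such as a carboxylic acid or hydroxymethyl, would stay within the scatter of compound 1 at 1.2 ug/mL. Also open, on these data alone, is how a longer chain, such as propoxy in place of the ethoxy of compound 2, would read in a core that still gives numbers, which would show whether lengthening this chain has any measurable size.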